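The source may hold more compounds than are shown below. What is called first, only, known or untested is meant among the compounds shown, and "the series" means these compounds.

Measured in an ADME assay on S9 fraction from liver (Rattus norvegicus) for metabolic stability, with a stated time of 1 h; on this read-out higher numbers stand for a more stable compound and lower numbers for a less stable compound:
Compound 1 `N#Cc1cnc(NCc2cnccc2C(F)(F)F)cc1N[C@H]1C[C@H](O)C1`: 82%
Compound 2 `N#Cc1cnc(NCc2cnccc2C(F)(F)F)cc1NC[C@H]1CC[C@H](O)CC1`: 6%

Of these two numbers, compound 2 holds the lower, and the gap to compound 1 lies beyond the scatter. Compound 3 `N#Cc1cnc(NCc2cnccc2C(F)(F)F)cc1NCCC1CCOCC1` has not yet been measured in this assay. It arises from compound 2 by one change: (oxan-4-yl)methyl in place of 4-hydroxycyclohexyl on a saturated chain carbon bound to a nitrogen on an aromatic ring. Among the measured compounds shown here, only one measured step bears on this, and only loosely: a number 76 percentage points lower from compound 1 to compound 2 (beyond the scatter). For the measured compounds named here, that large step also concerns the group on the nitrogen, but it is a different exchange, and no measured compound carries the 2-(oxan-4-yl)ethyl group. With compound 2 at 6%, little room is left for a fall, so any clear move is expected to be upward. The expected step, moderate and uncertain, is a number 19 percentage points higher from compound 2 to compound 3 (beyond the scatter). For compound 3 the estimated value is 25%, with an expected range of 5% to 60%.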

Compound 3, percent of the compound remaining: 0%
The estimate for compound 3 lay 25 percentage points above the measured number, and the stated range ends above it.
By their numbers in this assay, from the lowest: compounds 3 and 2 (each within the scatter of the next); then compound 1.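

In this assay, (oxan-4-yl)methyl in place of 4-hydroxycyclohexyl gives a number 6 percentage points lower from compound 2 to compound 3 (within the scatter), so this exchange on a saturated chain carbon bound to a nitrogen on an aromatic ring does not separate the two compounds, even though the entering group has no hydrogen-bond donor and the leaving group has one. The wider exchange of 3-hydroxycyclobutyl for 2-(oxan-4-yl)ethyl on a nitrogen on an aromatic ring gives a number 82 percentage points lower from compound 1 to compound 3 (beyond the scatter), which places compound 3 with compound 2, far from compound 1. No evidence at hand accounts for these numbers.

The compounds shown leave open whether the chain or the six-membered ring sets the gap to compound 1, since both differ at once. An oxan-4-yl group bound directly to that nitrogen, or a (3-hydroxycyclobutyl)methyl group there, would separate the two.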